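Working notes: cyclohexyl in place of methyl

This account rests on a few compounds, and the source may have more. Where it says the series, first, only, none or still open, it means among the compounds named here.

Among the compounds with values here, in a functional assay on brain (Rattus norvegicus, strain Wistar) for inhibition (a lower number here means a stronger inhibitor, a higher number a weaker inhibitor), compound 1 (`CCCCc1ccc(-c2c(C)[nH]c(=O)n2C2CCCCC2)cc1`) gives 27100 nM as the lower of the two numbers so far. Compound 2 (`COc1ccc(-c2c(C)[nH]c(=O)n2C)cc1`) reads 147000 nM as the higher number and so the weaker inhibitor of the pair, with a gap beyond the usual scatter. Compound 3 (`COc1ccc(-c2c(C)[nH]c(=O)n2C2CCCCC2)cc1`) differs from compound 2 in one place: cyclohexyl in place of methyl on an aromatic nitrogen. Within the data shown here, compound 1 and compound 2 differ in more than one place, so no measured pair isolates this change. Compound 1 also bears cyclohexyl and stands at 27100 nM in this series, so a moderate drop in this assay is expected, probably beyond the scatter but uncertain. The expected change is a 2.7-fold lower number from compound 2 to compound 3 (0.43 log units; beyond the scatter) on this estimate. Compound 3 is estimated at 55000 nM with an expected range from 20000 nM to 150000 nM for the coming measurement.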

Compound 3, half-maximal inhibitory concentration: 20400 nM
For compound 3 the middle estimate is 2.7-fold (0.43 log units) above the measured one; the measured number falls inside the stated range.
By their numbers in this assay, from the lowest: compounds 3 and 1 (each within the scatter of the next); then compound 2.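

Working notes, reading the result: In this assay, the substituent on the aromatic nitrogen now has a direct reading, with cyclohexyl in place of methyl giving a 7.2-fold lower number from compound 2 to compound 3 (0.86 log units; beyond the scatter) while the methoxy group stays fixed. With cyclohexyl held in place, methoxy in place of butyl on an aromatic carbon gives a 1.3-fold lower number from compound 1 to compound 3 (0.12 log units; within the scatter), so this exchange does not separate the two compounds in this assay. Nothing at hand explains either step.

Going by these compounds, whether the lower number depends on the ring itself or would also follow from a cyclopentyl, a phenyl or an open hexyl chain on that nitrogen remains open. Also open is whether the cyclohexyl step carries over to the butyl compounds, as the compounds shown include no butyl partner with methyl on the nitrogen.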